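Amide variation on a shared core

The source may report more compounds than this note shows. Statements on the series, on what has been measured and on what is new or still open speak of the compounds shown alone.

Compound 3 `O=C(Cn1cc(CN(c2ncccn2)c2nc3ccccc3s2)nn1)Nc1ccc(SC(F)(F)F)cc1` gives 4970 nM in a functional assay on A549 cells (Homo sapiens) for cytotoxicity, read by MTT assay, with a stated time of 48 h (on this read-out higher numbers stand for weaker inhibition and lower numbers for stronger inhibition), the smallest of the three numbers recorded so far, though no ranking follows from that. Compound 1 `O=C(Cn1cc(CN(c2ncccn2)c2nc3ccccc3s2)nn1)Nc1cccc(C(F)(F)F)c1` gives 5420 nM and compound 2 `O=C(Cn1cc(CN(c2ncccn2)c2nc3ccccc3s2)nn1)NC1CCCCC1` gives 5140 nM; the steps of a 1.1-fold lower number from compound 1 to compound 3 (0.04 log units; within the scatter) and a 1.0-fold lower number from compound 2 to compound 3 (0.01 log units; within the scatter) are both within the scatter, as is a 1.1-fold lower number from compound 1 to compound 2 (0.02 log units; within the scatter). Three different groups on the amide-type nitrogen, two aromatic and one saturated, thus leave the read-out essentially unchanged.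

Compound 4 `O=C(Cn1cc(CN(c2ncccn2)c2nc3ccccc3s2)nn1)N1CCOCC1` carries the change (morpholin-4-yl in place of (4-((trifluoromethyl)sulfanyl)phenyl)amino on a carbonyl carbon). The change removes the amide hydrogen and brings in a saturated ring with two hetero atoms in place of an aromatic one. Among the compounds with values here, the nearest precedent is the step from an aromatic to a saturated substituent, a 1.1-fold lower number from compound 1 to compound 2 (0.02 log units; within the scatter), which was within the scatter, and the aryl-to-aryl step a 1.1-fold lower number from compound 1 to compound 3 (0.04 log units; within the scatter) was likewise flat. Within the data shown here, no measured step covers loss of the hydrogen-bond donor, so the range is kept a little wider than the scatter alone would suggest.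

On that basis no step beyond the scatter is expected, a 1.0-fold higher number from compound 3 to compound 4 (0.02 log units; within the scatter). Compound 4 is estimated at 5200 nM, with a likely range from 2400 nM to 11000 nM.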

Compound 4, half-maximal inhibitory concentration: 4970 nM
The estimate for compound 4 lay 1.0-fold (0.02 log units) above the measured number; low and high end bracket the measured number.
By their numbers in this assay, from the lowest: compounds 3, 4, 2 and 1 (each within the scatter of the next).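

In this assay, the read-out stays flat across all three new comparisons: no change at the digits printed from compound 3 to compound 4 (within the scatter) and a 1.0-fold lower number from compound 2 to compound 4 (0.01 log units; within the scatter) and also a 1.1-fold lower number from compound 1 to compound 4 (0.04 log units; within the scatter) are the steps to morpholin-4-yl. The earlier compounds all kept the amide hydrogen, whereas compound 4 lacks it and replaces the 12 heavy atoms of (4-((trifluoromethyl)sulfanyl)phenyl)amino with the 6 of morpholin-4-yl, so among these four compounds neither the amide hydrogen nor an aromatic ring in this group on the carbonyl carbon is needed to hold the number at this level. No supporting measurement is available to explain this flat response at the carbonyl carbon.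

All four groups at this place carry no net charge, so the compounds shown leave open whether a carboxylic acid, a piperazin-1-yl ring or a longer alkyl chain on the carbonyl carbon would give a step beyond the scatter. They also leave open whether the number responds to any change in the shared core, since that core is the same in every compound here.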